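Two Values and an Acetyl Group Replaced by Methyl

The source may report more compounds than this note shows. Statements on the series, on what has been measured and on what is new or still open speak of the compounds shown alone.

Compound 1 `COC/C1=C/C[C@](C)(CCC=C(C)C)/C=C/[C@@H](OC(=O)C=C(C)C)[C@](C)(OC)/C=C/C1=O`: 4050 nM
Compound 2 `CC(=O)O[C@]1(C)/C=C/C(=O)/C(CO)=C\C[C@](C)(CCC=C(C)C)/C=C/[C@H]1OC(=O)C=C(C)C`: 2370 nM

In a functional assay on HL-60 cells (Homo sapiens) for antiproliferative activity, read by MTT assay, with a stated time of 48 h (on this read-out lower numbers stand for stronger inhibition and higher numbers for weaker inhibition), compound 2 gives 2370 nM. For the measured compounds named here, that value lies within the usual scatter of the one for compound 1, at 4050 nM, so the two numbers set no order between the compounds.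

The next compound to be tested is compound 3 `CO[C@]1(C)/C=C/C(=O)/C(CO)=C\C[C@](C)(CCC=C(C)C)/C=C/[C@H]1OC(=O)C=C(C)C`, which has methyl in place of acetyl on an oxygen on a saturated carbon. Going by the values given here, no measured pair shows this change on its own, so the data offer no direct guide to its size. With both measured values so close, no step beyond the scatter is expected in this assay, and no clear direction is expected either. The estimated step is small: a 1.3-fold higher number from compound 2 to compound 3 (0.10 log units; within the scatter). For compound 3 the expected value is 3000 nM, with an estimated range of 1200 nM to 7500 nM.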

Compound 3, half-maximal inhibitory concentration: 14300 nM
For compound 3 the middle estimate is 4.8-fold (0.68 log units) below the measured one; the whole stated range lies below it.
By their numbers in this assay, from the lowest: compounds 2 and 1 (each within the scatter of the next); then compound 3.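

In this assay, the change from acetoxy to methoxy on the saturated carbon gives a step beyond the scatter, a 6.0-fold higher number from compound 2 to compound 3 (0.78 log units; beyond the scatter), so this position does not tolerate every small group on its oxygen equally. A second change, hydrogen in place of methyl on an oxygen on a saturated carbon, gives a step of similar standing, a 3.5-fold higher number from compound 1 to compound 3 (0.55 log units; beyond the scatter), so the number for compound 3 responds to more than one oxygen substituent. No measurement offered here explains either step.

The compounds shown leave open how a free hydroxyl, a longer acyl group such as propanoyl, or an amine would read on that saturated carbon. They also leave open whether either step would hold with a longer ether chain in place of methyl.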